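This account rests on a few compounds, and the source may have more. Where it says the series, first, only, none or still open, it means among the compounds named here.

Measured so far in the series:
- compound 1 `CCCc1cc(N)c2cc(NC(=O)/C=C/c3ccc(Cl)cc3Cl)ccc2n1`: 6.6 nM
- compound 2 `CCCc1ccc(/C=C/C(=O)Nc2ccc3nc(CCC)cc(N)c3c2)cc1`: 4 nM
- compound 3 `CCCc1cc(N)c2cc(NC(=O)/C=C/c3ccc(F)cc3)ccc2n1`: 130 nM

In an assay on isolated protein for displacement of a labelled ligand from melanin-concentrating hormone receptor 1 (Homo sapiens) (a lower number here means a stronger inhibitor, a higher number a weaker inhibitor), compound 3 gives 130 nM and stands highest of the three numbers: a 20-fold higher number from compound 1 to compound 3 (1.29 log units; beyond the scatter) and a 33-fold higher number from compound 2 to compound 3 (1.51 log units; beyond the scatter), both well beyond the scatter. The unmeasured compound 4 `CCCc1cc(N)c2cc(NC(=O)/C=C/c3ccccc3)ccc2n1` differs from compound 3 in one place: hydrogen in place of fluoro on an aromatic carbon. Within the data shown here, no measured pair covers the loss of a substituent at that position outright; the two steps that bear on it both end at compound 3 and show that exchanging the group on this ring moves the number strongly, the 4-fluorophenyl compound sitting far above the 4-propylphenyl and 2,4-dichlorophenyl compounds. Going from fluoro to hydrogen removes what little remains at that site, so the number is expected to stay at the weak end or drift somewhat higher, a modest step of a 1.9-fold higher number from compound 3 to compound 4 (0.28 log units; within the scatter) rather than a recovery. For compound 4 the estimate is 250 nM, with a range of 80 nM to 800 nM.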

Compound 4, half-maximal inhibitory concentration: 1000 nM
Estimate against measurement, compound 4: 4.0-fold (0.60 log units) below, and the stated range ends below it.
By their numbers in this assay, from the lowest: compounds 2 and 1 (each within the scatter of the next); then compound 3; then compound 4.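

In this assay the change from 4-fluorophenyl to phenyl is not silent: a 7.7-fold higher number from compound 3 to compound 4 (0.89 log units; beyond the scatter) shows that a single fluoro on the aromatic carbon para to a large group already counts for much of the number at this site. The other two steps give the full span on this ring, with a 250-fold higher number from compound 2 to compound 4 (2.40 log units; beyond the scatter) and a 150-fold higher number from compound 1 to compound 4 (2.18 log units; beyond the scatter) leaving compound 4 the weakest of the four, and each of the three substituted rings shown gives a lower number than the unsubstituted phenyl. Nothing measured here accounts for the size of these steps.

The compounds shown do not tell whether an amine, a carboxylic acid or a chain longer than propyl on that same aromatic carbon would keep the number low. They also do not separate the contributions of the two chloro groups in the 2,4-dichlorophenyl compound.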